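Alkynyl phenylpropanoic acids: methoxy for 2-methylphenyl

This account rests on a few compounds, and the source may have more. Where it says the series, first, only, none or still open, it means among the compounds named here.

Measured so far:
compound 1, `O=C(O)CCc1ccc(C#Cc2ccnc(F)c2)cc1`, 98%
compound 2, `Cc1ccccc1-c1cc(C#Cc2ccc(CCC(=O)O)cc2)ccn1`, 92%

Compound 2 stands lowest of the two numbers in an in vitro functional assay on 1321-N1 cells for agonist activity at Free fatty acid receptor 1 (Homo sapiens), read by fluorescence, spectrophotometry and calcium flux (on this read-out lower numbers stand for smaller maximal responses and higher numbers for larger maximal responses), with compound 1 nearest at a number 6 percentage points lower from compound 1 to compound 2 (within the scatter). Both compounds therefore reach essentially the same maximal response in this assay, and no order between them can be claimed.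

Compound 3, `COc1cc(C#Cc2ccc(CCC(=O)O)cc2)ccn1`, is not yet measured. It differs from compound 2 as follows: methoxy in place of 2-methylphenyl on an aromatic carbon. Going by the values given here, the only step known at this position, a number 6 percentage points lower from compound 1 to compound 2 (within the scatter), swapped a small group for a large one and left the efficacy unchanged within the scatter. Among the compounds with values here, on that basis no step beyond the scatter is expected in this assay from compound 2 to compound 3, although a single step is a thin basis and the methoxy group has no precedent here.

For compound 3 the expected efficacy in this assay is 95%, range 80% to 105%, an estimated step of a number 3 percentage points higher from compound 2 to compound 3 (within the scatter).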

Compound 3, largest response reached (reported as efficacy), in percent of the reference or control that the assay uses: 98%
The estimate for compound 3 lay 3 percentage points below the measured number; the measured number falls inside the stated range.
By their numbers in this assay, from the lowest: compounds 2, 1 and 3 (each within the scatter of the next).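

In this assay, methoxy, with no ring and a hydrogen-bond acceptor, in place of 2-methylphenyl, a six-membered aromatic ring of carbon only, gives a number 6 percentage points higher from compound 2 to compound 3 (within the scatter), so the aromatic carbon next to the ring nitrogen can lose that ring with the maximal response staying within the scatter. Methoxy in place of fluoro gives no change at the digits printed from compound 1 to compound 3 (within the scatter), which makes three groups at this carbon, fluoro, 2-methylphenyl and methoxy, that this assay does not separate. Nothing available explains why these three groups do not separate.

On these data alone, whether an amine or a carboxylic acid on this carbon would keep the maximal response remains open, as does the outcome for a longer chain on the oxygen. Maximal response alone also leaves the potency of these compounds open.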